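The compounds below may be only part of what the source reports. "The series", "measured", "known", "first", "only" and "open" are said of these compounds alone.

Values in a functional assay on HL-60 cells (Homo sapiens) for cytotoxicity, read by luminescence and CellTiter-Glo, with a stated time of 3 days; on this read-out lower numbers stand for stronger inhibition and higher numbers for weaker inhibition:
Compound 1 `N#Cc1ccc(NC(=O)c2cc(Br)c3cccnc3c2O)cc1`: 330 nM
Compound 2 `Cc1cc(C#N)ccc1NC(=O)c1ccc2cccnc2c1O`: 710 nM
Compound 3 `N#Cc1ccc(NC(=O)c2ccc3cccnc3c2O)cc1`: 370 nM

Compound 3 sits within the usual scatter of both other compounds, and the measured steps to it are a 1.1-fold higher number from compound 1 to compound 3 (0.05 log units; within the scatter) and a 1.9-fold lower number from compound 2 to compound 3 (0.28 log units; within the scatter). Compound 4 `O=C(Nc1ccc(C(F)(F)F)cc1)c1ccc2cccnc2c1O` has not yet been measured. It keeps the shared core of compound 3 but carries trifluoromethyl in place of cyano on an aromatic carbon, para to a large group: trifluoromethyl in place of cyano on an aromatic carbon. The two measured steps replace bromo and methyl with hydrogen, and the cyano group stays in place throughout. They therefore bear on this swap only indirectly, and the data contain no direct test of it. With compound 3 at 370 nM and both of its measured steps within the scatter, no step beyond the scatter is expected in this assay, although the range must stay wide. The estimated step is a 1.1-fold higher number from compound 3 to compound 4 (0.03 log units; within the scatter). For compound 4 the estimated value is 400 nM, with an expected range from 150 nM to 1100 nM.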

Compound 4, half-maximal inhibitory concentration: 680 nM
Compound 4: middle estimate off by 1.7-fold (0.23 log units), on the low side; measured number inside the range.
By their numbers in this assay, from the lowest: compounds 1, 3, 4 and 2 (each within the scatter of the next, the first and the last beyond it).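

For the compounds shown here, compound 4 is the first direct test of the group on this aromatic carbon. The earlier compounds shown here all keep the nitrile there. In this assay, replacing cyano with trifluoromethyl gives a 1.8-fold higher number from compound 3 to compound 4 (0.26 log units; within the scatter), so the two compounds cannot be told apart here, even though the group that enters has more heavy atoms and, by the count, no hydrogen-bond acceptor. Nothing measured here accounts for this result.

The compounds shown leave open how an amine or a carboxylic acid on this same aromatic carbon would read, and whether such a group would stay within the scatter of compound 3. They also leave open whether trifluoromethyl at this place behaves the same way when bromo is present on the shared core.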